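Distribution coefficients across three measured compounds and one estimate

A few compounds are considered here, and "the series" means these few. Any claim that something is new, unique, unknown or untested is made for them only; others in the source may bear on it.

Measured so far:
compound 1 `CC(=O)NCCC(CC(=O)Nc1ccc(C)cc1C)c1nnc(CCCC(C)C)n1C1CC1` – 3.5
compound 2 `Cc1ccc(NC(=O)C[C@H](CCC(=O)O)c2noc(-c3cc(CC(C)C)on3)c2C2CC2)c(Cl)c1` – 3.9
compound 3 `CC(C)(C)Cc1cc(-c2onc([C@@H](CCC(=O)O)CC(=O)Nc3ccc(Cl)cc3Cl)c2C2CC2)no1` – 4.2

In a physicochemical assay for lipophilicity (a lower number here means a more polar compound, a higher number a more lipophilic compound), compound 2 gives 3.9. Among the three numbers this is the second highest. The nearest is compound 3, whose number is higher by an amount within the scatter, so no order between compound 2 and compound 3 can be claimed. The furthest is compound 1, whose number is lower by an amount beyond the scatter; compound 2 is thus more lipophilic than compound 1 in this assay.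

The next compound, compound 4 `Cc1ccc(NC(=O)C[C@H](CCC(=O)O)c2noc(-c3cc(C(F)(F)C(C)(C)C)on3)c2C2CC2)c(Cl)c1`, is not yet measured. It differs from compound 2 in one place:

1,1-difluoro-2,2-dimethylpropyl in place of isobutyl on an aromatic carbon

For the measured compounds named here, no step between measured compounds is available to anchor this change, so the expectation rests on compound 2 alone and on what enters and leaves. With the 1,1-difluoro-2,2-dimethylpropyl group carrying more heavy atoms than the isobutyl group it replaces, the step from compound 2 to compound 4 is expected to be an increase, likely beyond the scatter, of about a number 0.40 log units higher from compound 2 to compound 4 (beyond the scatter). Compound 4 is therefore estimated at 4.3 in this assay, within a range of 3.8 to 4.8.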

Compound 4, distribution coefficient: 4.3
Compound 4: middle estimate and measured number agree at the digits printed; low and high end bracket the measured number.
By their numbers in this assay, from the lowest: compound 1; then compounds 2, 3 and 4 (each within the scatter of the next, the first and the last beyond it).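

In this assay, the position on an aromatic carbon next to the ring oxygen now has its first reading for a single change: 1,1-difluoro-2,2-dimethylpropyl in place of isobutyl gives a number 0.40 log units higher from compound 2 to compound 4 (beyond the scatter) on an otherwise unchanged structure. For the compounds shown here, no earlier pair differed in one place, and this step shows that the position does not leave the read-out flat when 7 heavy atoms replace 4 heavy atoms, with no hydrogen-bond donors or acceptors on either group. Nothing measured here ties the step to a cause.

Still open, going by these compounds, is how a tert-butyl or a trifluoromethyl group at this position would read in this assay, and thus how the added carbon and the fluorine share in the step. Also open, on these data alone, is whether the same change gives a step of like size on the core of compound 1.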